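Methoxy for Chloro on a Second Ring Position

The source may hold more compounds than are shown below. What is called first, only, known or untested is meant among the compounds shown, and "the series" means these compounds.

Compound 1 `Clc1ccc2[nH]c(-c3cn(-c4ccccc4)nc3-c3ccccc3)nc2c1` was tested in a functional assay on A549 cells (Homo sapiens) for antiproliferative activity, read by MTT assay, with a stated time of 48 h (on this read-out lower numbers stand for stronger inhibition and higher numbers for weaker inhibition), and gives 2370 nM. Compound 2 `COc1ccc2[nH]c(-c3cn(-c4ccccc4)nc3-c3ccccc3)nc2c1` carries methoxy in place of chloro on an aromatic carbon and in this assay gives 1230 nM, a step of a 1.9-fold lower number from compound 1 to compound 2 (0.28 log units; within the scatter). Compound 3 `Fc1ccc2[nH]c(-c3cn(-c4ccccc4)nc3-c3ccc(Cl)cc3)nc2c1` gives 4610 nM in this assay; its core differs from that of compound 1, but that difference is not broken down here. The gap between compound 3 and compound 1 stays within the scatter, while compound 3 sits beyond the scatter from compound 2.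

Compound 4 `COc1ccc(-c2nn(-c3ccccc3)cc2-c2nc3cc(F)ccc3[nH]2)cc1` has not yet been measured. Relative to compound 3 it shows (methoxy in place of chloro on an aromatic carbon). Going by the values given here, this is the same kind of change as the one from compound 1 to compound 2, but not the same: there the aromatic carbon belonged to a ring that is part of a fused system of two rings, meta and para to a fused ring, whereas here the ring is of carbon only and the site is para to a large group.

Because a 1.9-fold lower number from compound 1 to compound 2 (0.28 log units; within the scatter) stayed within the scatter, a comparable step is expected for compound 4, estimated as a 1.6-fold lower number from compound 3 to compound 4 (0.22 log units; within the scatter). Compound 4 is thus expected to give about 2800 nM in this assay, plausibly between 1200 nM and 6500 nM.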

Compound 4, half-maximal inhibitory concentration: 1980 nM
For compound 4 the middle estimate is 1.4-fold (0.15 log units) above the measured one, and the stated range covers the measured number.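

In this assay, the change from 4-chlorophenyl to 4-methoxyphenyl gives a 2.3-fold lower number from compound 3 to compound 4 (0.37 log units; beyond the scatter). Set beside the same swap of chloro for methoxy at a different site on another core, this step points the same way, and the two steps agree in size: the same change on two cores in this assay, a 1.9-fold lower number (0.28 log units; within the scatter) from compound 1 to compound 2 and a 2.3-fold lower number (0.37 log units; beyond the scatter) from compound 3 to compound 4, 1.2-fold (0.08 log units) apart, within the scatter of two such steps. So this swap gave a lower number on both cores, but two pairs cannot establish a rule for other cores, the earlier step alone lies within the scatter, and neither step explains why the number falls.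

The compounds shown leave open whether an amine, a carboxylic acid or a longer chain in place of the methoxy would move the number further, and in which direction. They also leave open whether the swap would give a similar step at other sites on these cores, or in a different assay.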